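One More Carbon: 4-Methylphenyl to 4-Ethylphenyl

This account rests on a few compounds, and the source may have more. Where it says the series, first, only, none or still open, it means among the compounds named here.

In a functional assay on MCF7 cells (Homo sapiens) for antiproliferative activity, with a stated time of 72 h (on this read-out higher numbers stand for weaker inhibition and lower numbers for stronger inhibition), compound 1 (`C/C(=C\c1csc(C)n1)[C@@H]1C[C@@H]2OC(c3ccccc3)=N[C@H]2CCC[C@H](C)[C@H](O)[C@@H](C)C(=O)C(C)(C)[C@@H](O)CC(=O)O1`) gives 19.2 nM and compound 2 (`C/C(=C\c1csc(C)n1)[C@@H]1C[C@@H]2OC(c3ccc(C)cc3)=N[C@H]2CCC[C@H](C)[C@H](O)[C@@H](C)C(=O)C(C)(C)[C@@H](O)CC(=O)O1`) gives 1.9 nM as the lower of the two numbers. Compound 3 (`CCc1ccc(C2=N[C@H]3CCC[C@H](C)[C@H](O)[C@@H](C)C(=O)C(C)(C)[C@@H](O)CC(=O)O[C@H](/C(C)=C/c4csc(C)n4)C[C@@H]3O2)cc1`) is still unmeasured. The change from compound 2 is methyl in place of hydrogen on a saturated chain carbon bound to an aromatic carbon, which turns 4-methylphenyl into 4-ethylphenyl. Within the data shown here, the one measured step that bears on this is a 10-fold lower number from compound 1 to compound 2 (1.00 log units; beyond the scatter) for methyl in place of hydrogen on an aromatic carbon. That step lies beyond the scatter, but it sits at a different place, so it is only a loose guide. For this assay a much smaller change is expected, and the estimated step is a 1.6-fold higher number from compound 2 to compound 3 (0.20 log units; within the scatter) toward a slightly higher number. Compound 3 is expected at 3 nM within a range from 0.8 nM to 12 nM in this estimate.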

Compound 3, half-maximal inhibitory concentration: 297 nM
Estimate against measurement, compound 3: 99-fold (2.00 log units) below; the measured number lies above the stated range.
By their numbers in this assay, from the lowest: compound 2; then compound 1; then compound 3.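

In this assay, one methyl in place of hydrogen on a saturated chain carbon bound to an aromatic carbon gives a 160-fold higher number from compound 2 to compound 3 (2.19 log units; beyond the scatter) and takes away the gain seen with 4-methylphenyl. Compared directly with the unsubstituted phenyl group, 4-ethylphenyl gives a 15-fold higher number from compound 1 to compound 3 (1.19 log units; beyond the scatter) in the opposite direction from a 10-fold lower number from compound 1 to compound 2 (1.00 log units; beyond the scatter) for methyl, so among these compounds a single added carbon turns a gain into a loss. No measurement shown here explains this reversal. The compounds shown leave open whether a longer chain such as propyl raises the number further. They also leave open whether a methoxy group or an amine at this place would keep the number low.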